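This account rests on a few compounds, and the source may have more. Where it says the series, first, only, none or still open, it means among the compounds named here.

Compound 1 `O=Cc1ccc(-c2cn3ccnc3c(-c3ccc4ncn(C5CCCCC5)c4c3)n2)cc1`: in a functional assay on SF-539 cells (Homo sapiens) for inhibition, read by sulforhodamine B assay, with a stated time of 48 h, tested at 10 uM (a higher number here means more inhibition at the concentration tested (going by the name of the read-out), a lower number less inhibition), compound 1 gives 31.5%. Compound 2 `Fc1ccc(-c2cn3ccnc3c(-c3ccc4ncn(C5CCCCC5)c4c3)n2)cc1`: compound 2 gives 17.3%. Compound 3 `CC(=O)c1ccc(-c2cn3ccnc3c(-c3ccc4ncn(C5CCCCC5)c4c3)n2)cc1`: compound 3 gives 2.82%.

Compound 3 stands lowest of the three, with compound 2 nearest to it and compound 1 furthest, both gaps beyond the scatter. Compound 4 `Fc1ccccc1-c1cn2ccnc2c(-c2ccc3ncn(C4CCCCC4)c3c2)n1` differs from compound 3 by 2-fluorophenyl in place of 4-acetylphenyl on an aromatic carbon. The step that bears most on this change is a number 14.5 percentage points lower from compound 2 to compound 3 (beyond the scatter), a modest fall when acetyl replaced fluoro; the exchange here runs the other way, though the fluorine now sits in the 2-fluorophenyl rather than in the earlier group. The step of a number 28.7 percentage points lower from compound 1 to compound 3 (beyond the scatter) adds that the acetyl compound sits lowest. Compound 4 is therefore expected to show a number 12.2 percentage points higher from compound 3 to compound 4 (beyond the scatter). The estimate for compound 4 is 15%, within 0% to 35%.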

Compound 4, a percentage reported as inhibition, at one concentration (the size of the read-out at that concentration, not a potency): 4.51%
Estimate against measurement, compound 4: 10.5 percentage points above; the measured number falls inside the stated range.
By their numbers in this assay, from the lowest: compounds 3 and 4 (each within the scatter of the next); then compound 2; then compound 1.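

In this assay, shifting from 4-fluorophenyl to 2-fluorophenyl gives a number 12.8 percentage points lower from compound 2 to compound 4 (beyond the scatter), so at this position the place of the fluorine on the phenyl ring matters, not just its presence. The exchange for 4-acetylphenyl gives a number 1.7 percentage points higher from compound 3 to compound 4 (within the scatter), leaving those two compounds level, while the exchange for 4-formylphenyl gives a number 27 percentage points lower from compound 1 to compound 4 (beyond the scatter), so compound 1 remains highest of the four. No evidence is available to explain these differences.

Going by these compounds, whether the formyl result reflects something particular to that group stays open. So does whether an amine or a carboxylic acid on the phenyl ring would match or pass compound 1.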